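This account rests on a few compounds, and the source may have more. Where it says the series, first, only, none or still open, it means among the compounds named here.

Compound 3 `COc1ccc(C(=O)Nc2ccccc2)cc1NC(C)=O` in an ADME assay on MDCK cells (Canis lupus familiaris) for cytotoxicity, read by cytopathic effect, with a stated time of 48 h (on this read-out higher numbers stand for lower toxicity in this test and lower numbers for higher toxicity in this test), reaches only the limit of the test, > 703 uM. Compound 2 `CCC(=O)Nc1cc(C(=O)Nc2nccs2)ccc1OC` likewise shows only a limit in this assay, > 655 uM. Compound 1 `CCC(=O)Nc1cc(C(=O)Nc2ccc(Br)cc2)ccc1OC` gives a numerical value in this assay, 90.4 uM. Within the data shown here, the one measured step, an at least 7.2-fold higher number from compound 1 to compound 2 (0.86 log units; beyond the scatter), alters the group on the amide-type nitrogen rather than the acyl end, and its size rests on a limit, (the limit of > 655 uM in this assay, at which 1 of the 3 values shown sits). Compound 4 `COc1ccc(C(=O)Nc2ccccc2)cc1NC(=O)C1CCCC1` differs from compound 3 by cyclopentyl in place of methyl on a carbonyl carbon. Among the measured compounds shown here, no measured step touches this position, so the only anchor is the ceiling at which compound 3 sits, (the limit of > 703 uM in this assay, at which 1 of the 3 values shown sits). Compound 4 is expected to return a number rather than a limit, a step of an at least 2.0-fold lower number from compound 3 to compound 4 (0.30 log units; that floor lies within the scatter), with an estimated value of 350 uM and a range of 80 uM to 900 uM.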

Compound 4, half-maximal toxic concentration: 459 uM
Compound 4: the middle estimate sits 1.3-fold (0.12 log units) below what was measured; the range from low to high includes it.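

The acyl end now has its first measured step in this assay, an at least 1.5-fold lower number from compound 3 to compound 4 (0.18 log units; that floor lies within the scatter). Cyclopentyl on this carbonyl carbon gives a number rather than a limit, but the printed floor does not establish a real change from methyl. The step is bounded on one side only, and the value for compound 3 is a limit: the limit of > 703 uM in this assay, at which 1 of the 4 values shown sits.

Still open, on these data alone, is whether a longer chain or a carboxylic acid at this carbonyl carbon would give a step beyond the scatter. Also open, as far as these compounds go, is whether cyclopentyl reads the same with 1,3-thiazol-2-yl or 4-bromophenyl on the amide-type nitrogen.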